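Cytotoxicity notes: hydrazone series, compound 2 to compound 3

The source may report more compounds than this note shows. Statements on the series, on what has been measured and on what is new or still open speak of the compounds shown alone.

Measured so far:
compound 1 `CN(C)CCn1cnnc1-c1cc(Oc2ccc(NC(=O)N/N=C/c3ccc(O)cc3)cc2F)ccn1` — "not determined" (no result reported) in an ADME assay on WI-38 cells (Homo sapiens) for cytotoxicity, read by MTT assay, with a stated time of 72 h; on this read-out higher numbers stand for weaker inhibition and lower numbers for stronger inhibition
compound 2 `CN(C)CCn1cnnc1-c1cc(Oc2ccc(NC(=O)N/N=C/c3ccc(O)c(Br)c3)cc2F)ccn1` — 5560 nM

Compound 1 carries no number in this assay, so compound 2 is the only entry with a measured value, and it stands alone; no ranking within the series is possible on what has been measured. In this assay compound 2 gives 5560 nM, a weak effect on the cell line.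

Compound 3 `Cc1cc(/C=N/NC(=O)Nc2ccc(Oc3ccnc(-c4nncn4CCN(C)C)c3)c(F)c2)cc(C)c1O` is still to be measured in this assay. It differs from compound 2 in one place: 4-hydroxy-3,5-dimethylphenyl in place of 3-bromo-4-hydroxyphenyl on a carbon with a double bond to nitrogen. The hydrogen-bond donor and acceptor counts of the group stay the same, the ring stays a six-membered aromatic ring of carbon only, and the shared core is untouched.

Going by the values given here, no measured step between compounds exists, so nothing shows how a change at this position moves the read-out. With only the value of compound 2 to rest on, the expectation for compound 3 is a step of a 1.1-fold higher number from compound 2 to compound 3 (0.03 log units; within the scatter) that stays within the usual scatter, in no particular direction. For compound 3 the estimate in this assay is therefore 6000 nM, expected to lie between 2500 nM and 15000 nM.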

Compound 3, half-maximal inhibitory concentration: 3610 nM
For compound 3 the middle estimate is 1.7-fold (0.22 log units) above the measured one, within the range that was stated.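

Cytotoxicity notes, continued: in this assay, 4-hydroxy-3,5-dimethylphenyl in place of 3-bromo-4-hydroxyphenyl on a carbon with a double bond to nitrogen gives a 1.5-fold lower number from compound 2 to compound 3 (0.19 log units; within the scatter). Going by these compounds alone, this is the first measured step at this position, and it shows that the read-out does not separate these two groups: the bromine leaves, two methyl groups enter, the hydrogen-bond donor and acceptor counts of the group stay the same, and the two compounds remain indistinguishable. Nothing available bears on why the two groups read alike.

One step within the scatter gives no direction for this position, and it cannot show whether any group placed here would move the read-out beyond the scatter, for example a carboxylic acid or an amine on the ring in place of the hydroxyl, or a methoxy group. The compounds shown also leave open how far this result carries over to changes in the shared core, and whether the same step would read alike on a different core.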